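Methyl on the Hydroxymethyl Oxygen of Compound 1

This account rests on a few compounds, and the source may have more. Where it says the series, first, only, none or still open, it means among the compounds named here.

Compound 1 `CCn1ccc(N2C[C@H](CO)OC2=O)c1` gives 300 nM in an assay for inhibition of Amine oxidase [flavin-containing] B (Bos taurus), read by fluorescence, with a stated time of 30 min (a higher number here means a weaker inhibitor, a lower number a stronger inhibitor), the lower of the two numbers measured. Compound 2 `COC[C@H]1CN(c2ccn(C)c2)C(=O)O1` gives 170000 nM in this assay, a much higher number. Compound 3 `CCn1ccc(N2C[C@H](COC)OC2=O)c1` is not yet measured; it differs from compound 1 by methyl in place of hydrogen on an oxygen on a saturated carbon, that is, hydroxy to methoxy. For the measured compounds named here, no step between measured compounds shows this change on its own, but compound 2, which also carries methoxymethyl, points to a weaker inhibitor. Compound 3 is therefore expected to give about 20000 nM (range 2000 nM to 170000 nM) in this assay, an estimated step of a 67-fold higher number from compound 1 to compound 3 (1.82 log units; beyond the scatter) beyond the scatter.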

Compound 3, inhibition constant: 1300 nM
Compound 3: middle estimate off by 15-fold (1.19 log units), on the high side; measured number below the stated range.
By their numbers in this assay, from the lowest: compound 1; then compound 3; then compound 2.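

Turning hydroxy into methoxy in this assay gives a 4.3-fold higher number from compound 1 to compound 3 (0.64 log units; beyond the scatter) and so costs far less than compound 2 suggested, which shows that the hydrogen on this oxygen is not essential for inhibition. The larger change is a 130-fold lower number from compound 2 to compound 3 (2.12 log units; beyond the scatter) for methyl in place of hydrogen on a saturated chain carbon bound to an aromatic nitrogen, so the high number of compound 2 lies mostly at that place rather than in its methoxymethyl. No supporting measurement explains either step.

On these data alone, how a longer chain on this oxygen, or an amine in place of the hydroxy, would read remains open.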